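A few compounds are considered here, and "the series" means these few. Any claim that something is new, unique, unknown or untested is made for them only; others in the source may bear on it.

The set comprises three measured compounds and one awaiting measurement. Compound 1 `Cc1cccc(/C(N)=N/NC(=S)N2CCCCC2)n1` gives 39% in a functional assay on MCF7 cells (Homo sapiens) for cytotoxicity, read by MTT assay, with a stated time of 72 h, tested at 10 uM; a lower number here means less inhibition of growth, a higher number more inhibition of growth at the concentration tested. Compound 2 `N/C(=N\NC(=S)N1CCOCC1)c1ccccn1` gives 66.7% in this assay. Compound 3 `Cc1ccnc(/C(N)=N/NC(=S)N2CCCCC2)c1` gives 40.7% in this assay. Among the three numbers, compound 3 stands second highest; its nearest neighbour is compound 1, whose number lies within the scatter of that of compound 3, and its furthest is compound 2, whose number lies beyond the scatter above it. Compound 4 `N/C(=N\NC(=S)N1CCCCC1)c1ccccn1` is the compound still to be measured. It differs from compound 3 in one place: hydrogen in place of methyl on an aromatic carbon. Among the compounds with values here, no step between two measured compounds that differ in only one place is available, so the size of this change cannot be read from a direct comparison. Compound 2, which also carries hydrogen rather than methyl on its ring, gives the highest of the three numbers, but it differs from compound 4 elsewhere as well, so its value offers only a hint. The step is therefore expected to be upward and moderate, a number 9.3 percentage points higher from compound 3 to compound 4 (within the scatter), and possibly beyond the scatter. Compound 4 is estimated at 50% in this assay, with a range from 30% to 72%.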

Compound 4, percent growth inhibition at one concentration: 53.1%
Beside the measured number, compound 4's estimate is 3.1 percentage points below it; low and high end bracket the measured number.
By their numbers in this assay, from the lowest: compounds 1 and 3 (each within the scatter of the next); then compound 4; then compound 2.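

In this assay, within the data shown here, hydrogen in place of methyl on the aromatic carbon meta to a large group and opposite the ring nitrogen gives a number 12.4 percentage points higher from compound 3 to compound 4 (beyond the scatter) and so provides the first direct reading of this change at this position. The same exchange made for the methyl of compound 1, which stands on a different ring carbon, gives a number 14.1 percentage points higher from compound 1 to compound 4 (beyond the scatter) and points the same way, so in both pairs the compound without a methyl inhibits growth more. With hydrogen on the ring, piperidin-1-yl in place of morpholin-4-yl on the thiocarbonyl carbon gives a number 13.6 percentage points lower from compound 2 to compound 4 (beyond the scatter) and shows that the group at this second place also moves the number once the ring methyl is absent.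

Nothing shown here explains why any of these steps occurs. Going by these compounds, it remains open whether an ethyl, a methoxy, a chlorine or an amine on the same aromatic carbon would go with a number like that of the methyl or the hydrogen compound, and whether the methyl exchange would give a similar step with morpholin-4-yl on the thiocarbonyl carbon.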